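The source may hold more compounds than are shown below. What is called first, only, known or untested is meant among the compounds shown, and "the series" means these compounds.

Compound 1 `COc1ccccc1N1C(=O)CSC1C(=O)NCCCCc1ccccc1`: 6%
Compound 2 `O=C(NCCCCc1ccccc1)c1cccc(C2SCC(=O)N2c2ccccc2)c1`: 68%

Of the compounds shown here, two have been measured in a functional assay on U2OS cells (Homo sapiens) for inhibition, read by CCK-8 assay, with a stated time of 72 h, tested at 1 uM; a lower number here means less inhibition, a higher number more inhibition at the concentration tested (going by the name of the read-out). Compound 1 gives 6%, while compound 2 gives 68%. Compound 2 thus stands highest of the two numbers; its nearest neighbour is compound 1, whose number lies well lower, a gap beyond the usual scatter. The two differ in more than one place, so no single structural change can be read off from their values.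

Compound 3 `COc1cc(F)ccc1N1C(=O)CSC1c1cccc(C(=O)NCCCCc2ccccc2)c1` has not yet been measured. It differs from compound 2 in one place: 4-fluoro-2-methoxyphenyl in place of phenyl on an amide-type nitrogen in a ring. Going by the values given here, no measured pair shows this exact change on the shared core, so its effect is not known from the data. Because compound 2 gives 68% and the change is confined to the ring on the amide-type nitrogen, compound 3 is expected to stay in the same general region, with a modest step down being the estimate, a number 13 percentage points lower from compound 2 to compound 3 (beyond the scatter). Compound 3 is therefore estimated at 55% in this assay, within a range from 25% to 80%.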

Compound 3, a percentage reported as inhibition, at one concentration (the size of the read-out at that concentration, not a potency): 34%
Compound 3: middle estimate off by 21 percentage points, on the high side; the measured number falls inside the stated range.
By their numbers in this assay, from the lowest: compound 1; then compound 3; then compound 2.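

In this assay, going by these compounds alone, the ring on the amide-type nitrogen proves to be a sensitive position: putting 4-fluoro-2-methoxyphenyl in place of phenyl gives a number 34 percentage points lower from compound 2 to compound 3 (beyond the scatter), and this is the first comparison here in which only one part of the molecule differs, so the drop can be tied to this single place. The new group brings a fluorine and a methoxy together, so this step describes the two as a single change, and the inhibition is reduced rather than lost, with compound 3 at 34%. No measurement shown here explains the drop.

From the compounds shown here alone, it remains open how much of the step belongs to the fluorine and how much to the methoxy, and whether a phenyl carrying only one of them would sit closer to compound 2. Also open, going by these compounds, is how this position would respond to a different kind of group on that ring, such as an amine or a carboxylic acid, and whether a longer chain on the amide would change the picture.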